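From phenyl to 1-methyl-1H-indol-5-yl

A few compounds are considered here, and "the series" means these few. Any claim that something is new, unique, unknown or untested is made for them only; others in the source may bear on it.

Going by the values given here, in a functional assay on B16-F0 cells (Mus musculus) for inhibition, read by CCK-8 assay, with a stated time of 48 h (a higher number here means a weaker inhibitor, a lower number a stronger inhibitor), compound 2 `COc1cc(-c2ccnc3cc(-c4ccccc4)nn23)cc(OC)c1OC` gives 4730 nM, the higher of the two numbers measured so far, which makes it the weaker inhibitor of the pair. Its closest relative, compound 1 `COc1cc(-c2ccnc3cc(-c4ccc(C)cc4)nn23)cc(OC)c1OC`, gives 21 nM. Among the compounds with values here, the one measured step is a 230-fold higher number from compound 1 to compound 2 (2.35 log units; beyond the scatter), and it comes with hydrogen in place of methyl on an aromatic carbon. Compound 3 `COc1cc(-c2ccnc3cc(-c4ccc5c(ccn5C)c4)nn23)cc(OC)c1OC` keeps the shared core but has 1-methyl-1H-indol-5-yl in place of phenyl on an aromatic carbon. Within the data shown here, no measured step covers this exact swap, so the evidence is thin. Still, the large change in a 230-fold higher number from compound 1 to compound 2 (2.35 log units; beyond the scatter) shows that a small addition to the phenyl can matter greatly in this assay. The expected step is a 79-fold lower number from compound 2 to compound 3 (1.90 log units; beyond the scatter), a large one towards a lower number. Compound 3 is estimated at 60 nM, with an expected range of 8 nM to 600 nM.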

Compound 3, half-maximal inhibitory concentration: 48 nM
For compound 3 the middle estimate is 1.3-fold (0.10 log units) above the measured one; measured number inside the range.
By their numbers in this assay, from the lowest: compound 1; then compound 3; then compound 2.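

Going by these compounds alone, at this aromatic carbon of the five-membered aromatic ring with 2 nitrogen, a small methyl on the phenyl is not the only change that lowers the number in this assay so sharply. Replacing phenyl with the larger 1-methyl-1H-indol-5-yl gives a 99-fold lower number from compound 2 to compound 3 (1.99 log units; beyond the scatter) and shows that this position accepts a second aromatic ring. Set against 4-methylphenyl, the same group gives a 2.3-fold higher number from compound 1 to compound 3 (0.36 log units; beyond the scatter) and is a modest step that leaves compound 1 with the lower number, and nothing measured here gives a reason for either step.

From the compounds shown here alone, it remains open whether the methyl on the indole nitrogen matters, and whether a 4-methoxyphenyl or 4-aminophenyl group would serve as well. A carboxylic acid or a longer chain, such as 4-butylphenyl, at this carbon would test how far the change can go.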